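Chloro to bromo on the fused ring: compound 3 to 4

The source may hold more compounds than are shown below. What is called first, only, known or untested is meant among the compounds shown, and "the series" means these compounds.

Measured so far:
compound 1 `COc1cccc(NC(=O)NC2CC(C)(C)Oc3ccc(Br)cc32)c1` — > 10000 nM
compound 2 `COc1ccc(NC(=O)NC2CC(C)(C)Oc3ccc(F)cc32)cc1` — 15500 nM
compound 3 `COc1ccc(NC(=O)NC2CC(C)(C)Oc3ccc(Cl)cc32)cc1` — > 30000 nM

The read-out is a functional assay (aorta) with Rattus norvegicus as the target; on this read-out lower numbers stand for an effect already at smaller amounts and higher numbers for an effect only at larger amounts of compound. Going by the values given here, compound 2 is the only member with a number, 15500 nM in this assay. For compound 1 the result is a limit, not a number, > 10000 nM (the limit of > 10000 nM in this assay, at which 1 of the 3 values shown sits). For compound 3 the result is likewise a limit, > 30000 nM (the limit of > 30000 nM in this assay, at which 1 of the 3 values shown sits), so compound 3 cannot be placed against the other two beyond saying that no number was reached.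

Compound 4 is `COc1ccc(NC(=O)NC2CC(C)(C)Oc3ccc(Br)cc32)cc1`. It differs from compound 3 by bromo in place of chloro on an aromatic carbon. Among the compounds with values here, the one measured step that bears on this is the halogen exchange on the same carbon: an at least 1.9-fold higher number from compound 2 to compound 3 (0.28 log units; that floor lies within the scatter). Its floor is within the scatter, so the fluoro-to-chloro swap gave no resolvable change, and compound 1, which already carries bromo, also ends at a limit. No basis appears for a step beyond the scatter from compound 3 to compound 4 in either direction.

Compound 4 is therefore expected to give 30000 nM in this assay, within 10000 nM to 100000 nM, most likely reported again as a limit. The expected step is a number no higher from compound 3 to compound 4 (the limit leaves the size open).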

Compound 4, half-maximal effective concentration: > 10000 nM
Compound 4: only a limit was reported; the forecaster's own chance of this, stated with the estimate: 80%; the middle value is on the limit's open side.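

In this assay compound 4 gives a limit, not a number, > 10000 nM. Going by these compounds alone, no step from compound 1, compound 2 or compound 3 to compound 4 can be read. Left open is whether bromo in place of chloro or fluoro on the aromatic carbon shifts the read-out at all, with compound 2 the only member holding a number.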